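Swapping a Chlorine-Bearing Ring End for a Methyl-Bearing One

The compounds below may be only part of what the source reports. "The series", "measured", "known", "first", "only" and "open" are said of these compounds alone.

Of the compounds shown here, three have been measured in an ADME assay on a cell-free system (plasma, Rattus norvegicus) for metabolic stability, read by LC-MS, with a stated time of 60 min, tested at 100 uM; a higher number here means that more of the compound is left, a lower number that less of the compound is left. Compound 1 `COc1cc(C(=O)O)ccc1OCCCCOc1ccc(C(=O)CC(C)(C)C)c(O)c1C` gives 48%. Compound 3 `CCC(=O)c1ccc(OCCCCOc2ccc(F)c(C(=O)O)c2)c(C)c1O` gives 96%. Compound 2 `Cc1c(OCCCCOc2ccc(C(=O)O)cc2Cl)ccc(C(=O)CC2CCCC2)c1O` gives 120%, the highest of the three numbers; its nearest neighbour is compound 3, a gap beyond the scatter, and the furthest is compound 1, a gap that is also beyond the scatter.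

Compound 4 `Cc1cc(OCCCCOc2ccc(C(=O)CC3CCCC3)c(O)c2C)ccc1C(=O)O` has not yet been measured in this assay. It differs from compound 2 in one place: 4-carboxy-3-methylphenyl in place of 4-carboxy-2-chlorophenyl on an oxygen on a saturated carbon.

Within the data shown here, no pair of measured compounds differing in a single place is available, so there is no direct guide for the size of such a step. Since compound 2 gives 120%, a number that already indicates nearly all of the material surviving, a step of a number 15 percentage points lower from compound 2 to compound 4 (beyond the scatter) is expected, a modest move downward that sits close to the scatter. Compound 4 is therefore estimated at 105%, within a range from 75% to 125%.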

Compound 4, percent of the compound remaining: 114%
Compound 4: the middle estimate sits 9 percentage points below what was measured; low and high end bracket the measured number.
By their numbers in this assay, from the lowest: compound 1; then compound 3; then compounds 4 and 2 (each within the scatter of the next).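

Among these compounds, the pair of compound 2 and compound 4 gives the first step in this assay that changes a single place: a number 6 percentage points lower from compound 2 to compound 4 (within the scatter). At this place, on an oxygen on a saturated carbon, 4-carboxy-3-methylphenyl in place of 4-carboxy-2-chlorophenyl therefore leaves the percent of the compound remaining unchanged within the scatter, so in this pair the chlorine is not needed to keep the number where it stands. What lies behind this result cannot be said, as nothing measured here speaks to it.

As far as these compounds go, it remains open whether the same swap would behave alike on the core of compound 1 or of compound 3. Also open, from the compounds shown here alone, is what an amine in place of the carboxylic acid, or a longer chain between the two oxygens, would do at this end of the molecule.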